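This account rests on a few compounds, and the source may have more. Where it says the series, first, only, none or still open, it means among the compounds named here.

Compound 1 (`Cc1ccc(C)c(NC(=O)Nc2nc(Sc3c[nH]c4ccccc34)cc(N3CCCCC3)n2)c1`) carries a urea on the shared core, and in a functional assay on PC-3 cells (Homo sapiens) for inhibition, with a stated time of 72 h (on this read-out lower numbers stand for stronger inhibition and higher numbers for weaker inhibition), compound 1 gives > 50000 nM, which is a limit of the assay rather than a number. Among the three compounds whose values are known, compound 1 stands at the limit of > 50000 nM in this assay, at which 1 of the 3 values shown sits. Compound 2 (`COc1ccc(NC(=O)Nc2nc(Sc3c[nH]c4ccccc34)cc(N3CCCC3)n2)cc1`) gives 21500 nM in this assay, and compound 3 (`Cc1cc(Cl)ccc1NC(=O)Nc1nc(Nc2ccccc2)cc(Sc2c[nH]c3ccccc23)n1`) gives 41900 nM. The next compound, compound 4 (`O=C(Nc1ccccc1)Nc1nc(Sc2c[nH]c3ccccc23)cc(N2CCCCC2)n1`), differs from compound 1 in one place: phenyl in place of 2,5-dimethylphenyl on an amide-type nitrogen. Within the data shown here, no step between two measured compounds that differ in one place has been recorded, so there is nothing in the numbers to set the size of this change. Given that every value known here sits at or close to the limit, the step from compound 1 to compound 4 is expected to be small, of the order of an at least 1.2-fold lower number from compound 1 to compound 4 (0.09 log units; that floor lies within the scatter), with no direction that clearly exceeds the scatter. For compound 4 the expected value in this assay is 40000 nM, within a range from 12000 nM to 50000 nM.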

Compound 4, half-maximal inhibitory concentration: 12100 nM
Estimate against measurement, compound 4: 3.3-fold (0.52 log units) above; the range from low to high includes it.
By their numbers in this assay, from the lowest: compounds 4, 2 and 3 (each within the scatter of the next, the first and the last beyond it). At a limit, above all of these: compound 1.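

In this assay the change of 2,5-dimethylphenyl to phenyl on an amide-type nitrogen gives the first single-place comparison (an at least 4.1-fold lower number from compound 1 to compound 4 (0.61 log units; beyond the scatter)), and the step lies beyond the usual scatter. Among these compounds, the earlier compounds differed from one another in more than one place, so only this pair shows that the group at this position alone can move the read-out with the rest of the molecule unchanged. Going by these compounds, compound 1 sits at a limit, so the step is a floor and its full size remains unknown: (the limit of > 50000 nM in this assay, at which 1 of the 4 values shown sits).

The compounds shown leave open whether one methyl group alone, at the 2 or the 5 position of the 2,5-dimethylphenyl, would account for the step. They also leave open how this position would respond to a benzyl group, a pyridine ring or a phenyl ring bearing a carboxylic acid.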